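The compounds below may be only part of what the source reports. "The series", "measured", "known", "first", "only" and "open" are said of these compounds alone.

Compound 1, `O/N=C(\CCN1CCN(c2ccccn2)CC1)c1cccc(F)c1`, gives 72% in a functional assay on HEK293 cells with D(4) dopamine receptor (Homo sapiens) as the target, read by FLIPR; a higher number here means a larger maximal response, a lower number a smaller maximal response.
Compound 2, `N#Cc1cccc(/C(CCN2CCN(c3ccccn3)CC2)=N/O)c1`, gives 48% in this assay.
Compound 3, `O/N=C(\CCN1CCN(c2ccccn2)CC1)c1ccc(Cl)cc1`, gives 46% in this assay.

Compound 3 has the lowest of the three numbers. Its nearest neighbour is compound 2, and that gap lies within the scatter (a number 2 percentage points lower from compound 2 to compound 3 (within the scatter)), so the two cannot be told apart. Compound 1 stands furthest away: a number 26 percentage points lower from compound 1 to compound 3 (beyond the scatter), a modest step beyond the scatter. Compound 4, `O/N=C(\CCN1CCN(c2ccccn2)CC1)c1ccc(F)cc1F`, has not yet been measured in this assay. The change from compound 3 is 2,4-difluorophenyl in place of 4-chlorophenyl on a carbon with a double bond to nitrogen. Within the data shown here, two measured steps bear on it. The step of a number 26 percentage points lower from compound 1 to compound 3 (beyond the scatter) shows that 4-chlorophenyl in place of 3-fluorophenyl lowered the maximal response modestly, while the step of a number 2 percentage points lower from compound 2 to compound 3 (within the scatter) shows that 3-cyanophenyl and 4-chlorophenyl give indistinguishable numbers. Among the measured compounds shown here, compound 4 brings back a fluorine-bearing ring, though with two fluorines rather than the single one of compound 1, so only a partial recovery is expected. For compound 4 the expected value is 55%, with a range from 40% to 72%. The expected step is a number 9 percentage points higher from compound 3 to compound 4 (within the scatter), which may well stay within the scatter.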

Compound 4, largest response reached (reported as efficacy), in percent of the reference or control that the assay uses: 78%
Estimate against measurement, compound 4: 23 percentage points below, outside the stated range (above it).
By their numbers in this assay, from the lowest: compounds 3 and 2 (each within the scatter of the next); then compounds 1 and 4 (each within the scatter of the next).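

In this assay, among these compounds, the carbon with a double bond to nitrogen proves able to carry a wider spread than the earlier compounds suggested: 2,4-difluorophenyl in place of 4-chlorophenyl gives a number 32 percentage points higher from compound 3 to compound 4 (beyond the scatter), and in place of 3-cyanophenyl it gives a number 30 percentage points higher from compound 2 to compound 4 (beyond the scatter). Against the single-fluorine ring there is only a number 6 percentage points higher from compound 1 to compound 4 (within the scatter), so among these four compounds the two fluorine-bearing rings cannot be told apart and both stand clear of the chlorine and nitrile rings. Nothing shown here explains this split.

On these data alone, whether a plain phenyl ring, or one carrying trifluoromethyl or methoxy, would fall with compound 1 and compound 4 or with compound 2 and compound 3 remains open. So does whether the split would survive a methyl ether in place of the hydroxyl on the shared core.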